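Two Halide Swaps on a Sulfonylated Benzimidazole Ether and Thioether

The source may report more compounds than this note shows. Statements on the series, on what has been measured and on what is new or still open speak of the compounds shown alone.

Compounds measured in an ADME assay on MT4 cells (Homo sapiens) for cytotoxicity, read by MTT assay, with a stated time of 5 days; a higher number here means that more compound is tolerated, a lower number that less compound is tolerated:
compound 1, `Cc1cc(C)cc(S(=O)(=O)n2c(OCC(=O)Nc3ccccc3Br)nc3ccccc32)c1`, gives > 243000 nM, which is a limit of the assay.
compound 2, `Cc1cc(C)cc(S(=O)(=O)n2c(OCC(=O)Nc3ccccc3Cl)nc3ccccc32)c1`, gives 169000 nM.
compound 3, `Cc1cc(C)cc(S(=O)(=O)n2c(SCC(=O)Nc3ccccc3Br)nc3ccccc32)c1`, gives >= 235000 nM, which is a limit of the assay.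

Compound 1 and compound 2 share a core and differ only by chloro in place of bromo on an aromatic carbon. That step amounts to an at least 1.4-fold lower number from compound 1 to compound 2 (0.15 log units; that floor lies within the scatter), and it starts from a limit, as recorded in the limit of > 243000 nM in this assay, at which 1 of the 3 values shown sits. Compound 3 carries a different core; how its core differs from that of compound 1 is not broken down here. Compound 3 itself sits at a limit, as recorded in the limit of >= 235000 nM in this assay, at which 1 of the 3 values shown sits.

Compound 4, `Cc1cc(C)cc(S(=O)(=O)n2c(SCC(=O)Nc3ccccc3Cl)nc3ccccc32)c1`, is not yet measured. It relates to compound 3 by chloro in place of bromo on an aromatic carbon, the same change as from compound 1 to compound 2. Compound 4 is expected to give about 200000 nM in this assay, between 120000 nM and 300000 nM. That expectation rests on compound 1 and compound 2, whose step an at least 1.4-fold lower number from compound 1 to compound 2 (0.15 log units; that floor lies within the scatter) stayed within scatter. The step of an at least 1.1-fold lower number from compound 3 to compound 4 (0.07 log units; that floor lies within the scatter) is therefore expected to be small, and compound 4 may well again return only a limit.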

Compound 4, half-maximal cytotoxic concentration: 107000 nM
Estimate against measurement, compound 4: 1.9-fold (0.27 log units) above; measured number below the stated range.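

In this assay, chloro in place of bromo on an aromatic carbon brings an at least 2.1-fold lower number from compound 3 to compound 4 (0.34 log units; beyond the scatter). Set beside the earlier step, only this one has a floor beyond the scatter, and whether the two steps truly differ remains unsettled: the same change on two cores in this assay, an at least 1.4-fold lower number (0.15 log units; that floor lies within the scatter) from compound 1 to compound 2 and an at least 2.1-fold lower number (0.34 log units; beyond the scatter) from compound 3 to compound 4; the limit leaves it open whether they differ

For compound 3, the reading of >= 235000 nM is a limit of the assay, so the new step gives only a floor and does not show how large the change really is, nor that it carries over from one core to the other at the same size.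

The compounds shown leave open how a fluoro or a methyl group in place of the bromo or chloro on the same aromatic carbon would read in this assay. They also leave open whether the swap from 2-bromophenyl to 2-chlorophenyl would give a similar step on a core that carries an amine or a longer chain.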